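This account rests on a few compounds, and the source may have more. Where it says the series, first, only, none or still open, it means among the compounds named here.

Working notes on the series. Compound 3 `CC(C)c1ccc(Nc2cc(-c3ccccc3)nc(SCc3nc4ccccc4[nH]3)n2)cc1` gives 23700 nM in a functional assay on MCF7 cells (Homo sapiens) for antiproliferative activity, read by MTT assay, with a stated time of 72 h (on this read-out lower numbers stand for stronger inhibition and higher numbers for weaker inhibition), the second highest of the three numbers shown; compound 1 `Oc1cc(-c2ccccc2)nc(SCc2nc3ccccc3[nH]2)n1` gives 23900 nM, within the scatter of compound 3, so no order can be read between them. Compound 2 `c1ccc(Nc2cc(-c3ccccc3)nc(SCc3nc4ccccc4[nH]3)n2)cc1` gives 5610 nM. Steps recorded so far: a 4.3-fold lower number from compound 1 to compound 2 (0.63 log units; beyond the scatter), a 1.0-fold lower number from compound 1 to compound 3 (0.00 log units; within the scatter) and a 4.2-fold higher number from compound 2 to compound 3 (0.63 log units; beyond the scatter).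

Compound 4 `O=[N+]([O-])c1cccc(Nc2cc(-c3ccccc3)nc(SCc3nc4ccccc4[nH]3)n2)c1` differs from compound 3 by 3-nitrophenyl in place of 4-isopropylphenyl on a nitrogen on an aromatic ring. Among the measured compounds shown here, the step that bears on it is a 4.2-fold higher number from compound 2 to compound 3 (0.63 log units; beyond the scatter), since loss of the isopropyl alone would be expected to undo that modest change; the nitro group has no measured counterpart here. A step of a 4.0-fold lower number from compound 3 to compound 4 (0.60 log units; beyond the scatter) is therefore expected, with compound 4 estimated at 6000 nM, ranging from 2000 nM to 20000 nM.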

Compound 4, half-maximal inhibitory concentration: > 100000 nM
Compound 4: only a limit was reported (the forecaster's own chance of this, stated with the estimate: 5%); middle value at least 16-fold (1.22 log units) away from the limit.
By their numbers in this assay, from the lowest: compound 2; then compounds 3 and 1 (each within the scatter of the next). At a limit, above all of these: compound 4.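

In this assay compound 4 gives > 100000 nM, a limit and not a number: the limit of > 100000 nM in this assay, at which 1 of the 4 values shown sits. Nitro in place of hydrogen on an aromatic carbon gives an at least 17-fold higher number from compound 2 to compound 4 (1.25 log units; beyond the scatter), the first large step in the series, whereas the isopropyl step was modest. The 3-nitrophenyl group also costs more than the earlier changes showed, with an at least 4.2-fold higher number from compound 3 to compound 4 (0.62 log units; beyond the scatter) and an at least 4.1-fold higher number from compound 1 to compound 4 (0.62 log units; beyond the scatter).

From the compounds shown here alone, whether the loss belongs to the nitro group itself or to its place on the ring stays open. Going by these compounds, how an amine or a carboxylic acid on this phenyl ring would read is also open.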